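Swapping the Amide Aryl Group in a Dopamine Receptor Series

A few compounds are considered here, and "the series" means these few. Any claim that something is new, unique, unknown or untested is made for them only; others in the source may bear on it.

Compound 1 `Cc1ccc(C(=O)NCN2CCC(c3cccc[n+]3[O-])CC2)cc1C`: 38 nM
Compound 2 `Cc1cccc(NC(=O)CN2CCC(c3nccs3)CC2)c1`: 1 nM
Compound 3 `Cc1cccc(NC(=O)CN2CCC(c3ccccc3)CC2)c1`: 170 nM

In a functional assay on HEK293 cells for agonist activity at D(4) dopamine receptor (Homo sapiens), read by FLIPR (on this read-out lower numbers stand for an effect already at smaller amounts and higher numbers for an effect only at larger amounts of compound), compound 1 sits second highest of the three numbers, above compound 2 and below compound 3. Among the compounds with values here, the only step between measured compounds that differ in one place is a 170-fold higher number from compound 2 to compound 3 (2.23 log units; beyond the scatter), which concerns the group on a saturated ring carbon, not the amide end; no measured step bears on the change now considered. Compound 4 `O=C(NCN1CCC(c2cccc[n+]2[O-])CC1)c1cnccc1Cl` differs from compound 1 by 4-chloropyridin-3-yl in place of 3,4-dimethylphenyl on a carbonyl carbon. With nothing to anchor the direction, compound 4 is expected to stay near compound 1, so the estimate is a 1.6-fold higher number from compound 1 to compound 4 (0.20 log units; within the scatter), with a wide range. For compound 4 the expected value is 60 nM, between 15 nM and 250 nM.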

Compound 4, half-maximal effective concentration: 1290 nM
Compound 4: middle estimate off by 22-fold (1.33 log units), on the low side, and the stated range ends below it.
By their numbers in this assay, from the lowest: compound 2; then compound 1; then compound 3; then compound 4.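

In this assay, the group on the carbonyl carbon proves to matter: with 4-chloropyridin-3-yl in place of 3,4-dimethylphenyl, there is a 34-fold higher number from compound 1 to compound 4 (1.53 log units; beyond the scatter), so this end of the molecule can move the number too, not only the group on a saturated ring carbon. Nothing available here explains the step.

The change brings in the ring nitrogen and the chlorine together and removes both methyl groups, and the compounds shown do not tell which of these goes with the step. A 4-chlorophenyl or a plain pyridin-3-yl on the carbonyl carbon would help separate them.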